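Swapping the Central Aryl Group: What to Expect for Compound 4

The compounds below may be only part of what the source reports. "The series", "measured", "known", "first", "only" and "open" are said of these compounds alone.

Compound 1 `O=c1oc2ccc(Cl)cc2c(O)c1C(c1cccc([N+](=O)[O-])c1)c1c(O)c2cc(Cl)ccc2oc1=O`: 27100 nM
Compound 2 `COc1ccc(C(c2c(O)c3cc(C)ccc3oc2=O)c2c(O)c3cc(C)ccc3oc2=O)cc1`: 107000 nM
Compound 3 `O=c1oc2ccc(Cl)cc2c(O)c1C(c1cccc(O)c1)c1c(O)c2cc(Cl)ccc2oc1=O`: 84100 nM

Of the compounds shown here, three that share the same core have been tested in an assay on isolated protein for inhibition of Maltase-glucoamylase (Homo sapiens); on this read-out higher numbers stand for weaker inhibition and lower numbers for stronger inhibition. Compound 1 stands lowest of the three, meaning it is the strongest inhibitor here; compound 3 sits nearest to it and compound 2 furthest away. Within the data shown here, the one change made at a single place is the exchange of nitro for hydroxy on an aromatic carbon, which gave a 3.1-fold higher number from compound 1 to compound 3 (0.49 log units; beyond the scatter), a modest weakening that lies beyond the usual scatter. Among the measured compounds shown here, compound 2 differs from compound 1 in more than one place, so its value shows only that a methoxy-bearing aryl group on a different core gives a far higher number than compound 1.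

Compound 4 `COc1cc(C(c2c(O)c3cc(Cl)ccc3oc2=O)c2c(O)c3cc(Cl)ccc3oc2=O)cc(OC)c1OC` has not yet been measured. It differs from compound 1 in one way: 3,4,5-trimethoxyphenyl in place of 3-nitrophenyl on a saturated chain carbon bound to two aromatic carbons. For the measured compounds named here, the only step that bears on this is the nitro-to-hydroxy exchange from compound 1 to compound 3, where removing the nitro group weakened inhibition. Replacing nitro by a trimethoxy-substituted ring is expected to behave in the same direction, so a modest rise in this assay is anticipated, roughly a 2.2-fold higher number from compound 1 to compound 4 (0.35 log units; beyond the scatter). Compound 4 is therefore estimated at 60000 nM, within a range of 20000 nM to 200000 nM.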

Compound 4, half-maximal inhibitory concentration: 128000 nM
Compound 4: middle estimate off by 2.1-fold (0.33 log units), on the low side, and the stated range covers the measured number.
By their numbers in this assay, from the lowest: compound 1; then compounds 3, 2 and 4 (each within the scatter of the next).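

In this assay, 3,4,5-trimethoxyphenyl in place of 3-nitrophenyl on a saturated chain carbon bound to two aromatic carbons gives a 4.7-fold higher number from compound 1 to compound 4 (0.67 log units; beyond the scatter), so a second, very different replacement of the 3-nitrophenyl group also raises the number beyond the scatter. The two replacements cannot be told apart, with a 1.5-fold higher number from compound 3 to compound 4 (0.18 log units; within the scatter), so among the compounds that differ only at this place, compound 1 stands alone, while compound 3 and compound 4 sit together despite carrying different groups on their rings. Nothing available explains why the 3-nitrophenyl compound gives the lowest number of this set.

Whether that low number belongs to the nitro group itself stays open, since the compounds shown include no plain phenyl group and no ring bearing a nitrile, a carboxylic acid or an amine at this place. They also leave open whether the same picture would hold on the core of compound 2, which is shown with only one group at this place, a methoxy-bearing ring.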